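The compounds below may be only part of what the source reports. "The series", "measured", "known", "first", "only" and "open" are said of these compounds alone.

Compound 1 `N#Cc1ccccc1N1CCN(C(=O)Cn2cnc([N+](=O)[O-])n2)CC1` – 213000 nM
Compound 2 `N#Cc1ccccc1N1CCN(CC(=O)N2CCN(c3ccccc3C#N)CC2)CC1` – 127000 nM

Both values come from an ADME assay on L6 cells (Rattus norvegicus) for cytotoxicity (a higher number here means a weaker inhibitor, a lower number a stronger inhibitor), and lie within the usual scatter of each other, so neither compound can be ranked over the other. Within the data shown here, compound 1 therefore sits alongside compound 2, the only other compound measured so far. Both carry the 2-cyanophenyl, so these two numbers do not show what replacing that group does.

Compound 3 `O=C(Cn1cnc([N+](=O)[O-])n1)N1CCN(c2ccc(Cl)c(Cl)c2)CC1` makes that replacement, with 3,4-dichlorophenyl in place of 2-cyanophenyl on an amine nitrogen in a ring. The swap counts as 3,4-dichlorophenyl in place of 2-cyanophenyl on an amine nitrogen in a ring and leaves the rest of the core of compound 1 unchanged. Among the measured compounds shown here, no measured step guides this expectation, so it rests on the structural change alone. A moderate move towards a lower number in this assay is expected, which would mean a stronger inhibitor, though the move may not clear the scatter by much. The estimated change is a 3.0-fold lower number from compound 1 to compound 3 (0.48 log units; beyond the scatter) and it carries real uncertainty. Compound 3 is expected at 70000 nM with an estimated range from 20000 nM to 220000 nM as the upper end.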

Compound 3, half-maximal inhibitory concentration: 108000 nM
For compound 3 the middle estimate is 1.5-fold (0.19 log units) below the measured one, within the range that was stated.
By their numbers in this assay, from the lowest: compounds 3, 2 and 1 (each within the scatter of the next).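

Placing 3,4-dichlorophenyl in place of 2-cyanophenyl on an amine nitrogen in a ring gives a 2.0-fold lower number from compound 1 to compound 3 (0.29 log units; within the scatter) in this assay. Among these compounds, this is the first direct reading of a change at this position, since compounds 1 and 2 both carry 2-cyanophenyl, and it shows that this swap does not separate compound 3 from compound 1: the nitrile and the one hydrogen-bond acceptor counted for the leaving group are gone, two chlorine atoms have entered, and the two compounds still cannot be ranked in this assay. No supporting measurement at hand explains this outcome.

Going by these compounds, with a single swap at this position, it remains open whether an unsubstituted phenyl, a phenyl carrying a single chlorine or one carrying a carboxylic acid would also stay within the scatter of compound 1 or would clearly differ from it. On these data alone, it is also open whether a non-aromatic group on the same ring nitrogen, such as a cyclohexyl ring or a short alkyl chain, would give a distinct reading in this assay.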